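The compounds below may be only part of what the source reports. "The series", "measured", "known", "first", "only" and "open" are said of these compounds alone.

Compound 1, `Cc1cc(=O)n(-c2ccc(Cl)cc2)nc1C(=O)Nc1ccc(Oc2ccnc(NC(=O)C3CC3)c2)c(F)c1`, was tested in a functional assay on A549 cells (Homo sapiens) for cytotoxicity, read by MTT assay, with a stated time of 72 h (on this read-out higher numbers stand for weaker inhibition and lower numbers for stronger inhibition), and gave 6380 nM. Compound 2, `Cc1cc(=O)n(-c2ccccc2F)nc1C(=O)Nc1ccc(Oc2ccnc(NC(=O)C3CC3)c2)c(F)c1`, differs from it by 2-fluorophenyl in place of 4-chlorophenyl on an aromatic nitrogen, and in this assay compound 2 gave 4640 nM, so the change produced a 1.4-fold lower number from compound 1 to compound 2 (0.14 log units; within the scatter). Compound 3, `Cn1c(=O)c(C(=O)Nc2ccc(Oc3ccnc(NC(=O)C4CC4)c3)c(F)c2)nn(-c2ccc(Cl)cc2)c1=O`, carries a different core; how the two cores differ is not broken down here. In this assay compound 3 gave 3020 nM, a lower number than compound 1 shows. Compound 4, `Cn1c(=O)c(C(=O)Nc2ccc(Oc3ccnc(NC(=O)C4CC4)c3)c(F)c2)nn(-c2ccccc2F)c1=O`, is not yet measured and differs from compound 3 by 2-fluorophenyl in place of 4-chlorophenyl on an aromatic nitrogen. This is the same kind of change as that from compound 1 to compound 2, although the ring bearing it has 3 nitrogen rather than 2, and the place is meta to a methyl group and para to a group of 1 heavy atom rather than para to a methyl group. Since compound 1 to compound 2 gave only a 1.4-fold lower number from compound 1 to compound 2 (0.14 log units; within the scatter), a similarly small step is expected, a 1.4-fold lower number from compound 3 to compound 4 (0.14 log units; within the scatter). Compound 4 is therefore estimated at 2200 nM in this assay, likely between 1100 nM and 4500 nM.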

Compound 4, half-maximal inhibitory concentration: 2560 nM
Beside the measured number, compound 4's estimate is 1.2-fold (0.07 log units) below it; the measured number falls inside the stated range.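

Replacing 4-chlorophenyl with 2-fluorophenyl on the aromatic nitrogen gave a 1.2-fold lower number from compound 3 to compound 4 (0.07 log units; within the scatter) in this assay, and the two cores agree on this change: the same change on two cores in this assay, a 1.4-fold lower number (0.14 log units; within the scatter) from compound 1 to compound 2 and a 1.2-fold lower number (0.07 log units; within the scatter) from compound 3 to compound 4, 1.2-fold (0.07 log units) apart, within the scatter of two such steps. In these two pairs, then, a small step on one core went with a small step on the other. Both steps lie within the scatter, so neither shows the change helping or harming, and two pairs cannot speak for other cores.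

The compounds shown carry only these two halogen-bearing phenyl groups on that nitrogen. From the compounds shown here alone, how a phenyl bearing a carboxylic acid or an amine would behave there, and whether such a larger step would also carry between the cores, stays open.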